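Swapping a Furan for a Dimethoxyphenyl Ring

The source may hold more compounds than are shown below. What is called first, only, known or untested is meant among the compounds shown, and "the series" means these compounds.

Compound 1, `COc1cc(-c2cc(-c3cc(C(C)C)c(O)cc3C)[nH]c(=O)c2C#N)cc(OC)c1OC`: 84.5%
Compound 2, `Cc1cc(O)c(C(C)C)cc1-c1cc(-c2ccco2)c(C#N)c(=O)[nH]1`: 70%

Both numbers come from a functional assay for inhibition, tested at 100 ug/mL; a higher number here means a stronger effect of the compound at the concentration tested, a lower number a weaker effect. Compound 2 stands lowest of the two, and its nearest neighbour, compound 1, sits higher by a gap beyond the usual scatter. Compound 3, `COc1ccc(-c2cc(-c3cc(C(C)C)c(O)cc3C)[nH]c(=O)c2C#N)cc1OC`, has not yet been tested in this assay. It differs from compound 2 in one place: 3,4-dimethoxyphenyl in place of furan-2-yl on an aromatic carbon. For the measured compounds named here, no step between two measured compounds is available here, so the size of the change can only be expected, not read off. Because compound 1 gives 84.5% in this assay, an upward step is expected for compound 3 rather than none. Compound 3 is expected to give about 80%, with a range from 65% to 92%. The step of a number 10 percentage points higher from compound 2 to compound 3 (within the scatter) is expected to lie beyond the scatter.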

Compound 3, a percentage reported as inhibition, at one concentration (the size of the read-out at that concentration, not a potency): 61%
The estimate for compound 3 lay 19 percentage points above the measured number; the measured number lies below the stated range.
By their numbers in this assay, from the lowest: compounds 3 and 2 (each within the scatter of the next); then compound 1.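

In this assay, 3,4-dimethoxyphenyl in place of furan-2-yl on the aromatic carbon ortho to a cyano group gives a number 9 percentage points lower from compound 2 to compound 3 (within the scatter), so at this position the six-membered carbon ring and the five-membered ring with its oxygen cannot be told apart. Hydrogen in place of methoxy on an aromatic carbon gives a number 23.5 percentage points lower from compound 1 to compound 3 (beyond the scatter), which shows that one methoxy on the phenyl ring moves the read-out beyond the scatter where the exchange of rings did not. Nothing at hand explains why the single methoxy matters here.

The compounds shown leave open whether that step depends on where the methoxy sits on the phenyl ring or on how many methoxy groups it carries. They also leave open how an ethoxy group, an amine or a carboxylic acid at that place on the phenyl ring would read in this assay.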